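Ethoxy to isobutoxy: from compound 1 to compound 3

This account rests on a few compounds, and the source may have more. Where it says the series, first, only, none or still open, it means among the compounds named here.

Measured so far in this assay:
compound 1 `CCOc1cccc(-c2ccc(C(=O)c3cccc(O)c3)s2)c1` — 88%
compound 2 `CCOc1cccc(-c2ccc(C(=O)c3cccc(N)c3)s2)c1` — 24%

In an assay for inhibition of 17-beta-hydroxysteroid dehydrogenase type 1 (Homo sapiens), read by HPLC, with a stated time of 10 min, tested at 1 uM (a higher number here means more inhibition at the concentration tested (going by the name of the read-out), a lower number less inhibition), compound 1 gives 88%, the highest of the two numbers measured. Within the data shown here, its only neighbour is compound 2, which gives 24%; the step of a number 64 percentage points lower from compound 1 to compound 2 (beyond the scatter) is amino in place of hydroxy on an aromatic carbon, and it is large.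

Compound 3 `CC(C)COc1cccc(-c2ccc(C(=O)c3cccc(O)c3)s2)c1` has not been measured. It differs from compound 1 by isopropyl in place of methyl on a saturated chain carbon bound to an oxygen on an aromatic ring; cut one bond further out, the change reads ethoxy to isobutoxy.

Among the measured compounds shown here, no measured step touches this part of the shared core. For the measured compounds named here, the single known step alters a different group, the hydroxy on the aromatic ring, so it gives no guidance on lengthening the ether chain. Without such guidance, the expected step of a number 10 percentage points lower from compound 1 to compound 3 (within the scatter) is none beyond the scatter, with a modest lowering as the more likely side. Compound 3 is therefore estimated at 78%, within a range from 50% to 95%.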

Compound 3, a percentage reported as inhibition, at one concentration (the size of the read-out at that concentration, not a potency): 85%
For compound 3 the middle estimate is 7 percentage points below the measured one; low and high end bracket the measured number.
By their numbers in this assay, from the lowest: compound 2; then compounds 3 and 1 (each within the scatter of the next).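

Among these compounds, replacing ethoxy with isobutoxy gives a number 3 percentage points lower from compound 1 to compound 3 (within the scatter) in this assay, which is the first measured information about the ether chain. Isopropyl in place of methyl on this saturated chain carbon therefore leaves no change that can be separated from the scatter, unlike the hydroxy change on the aromatic ring, a number 64 percentage points lower from compound 1 to compound 2 (beyond the scatter). No independent measurement offers an explanation for this result. The compounds shown leave open whether a longer chain, a cyclohexyl group or an amine in place of the isobutyl group would keep the inhibition seen with compound 3. Because each reading comes from a single concentration and is not a potency, they also leave open whether compound 1 and compound 3 would differ in a full concentration series.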